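A few compounds are considered here, and "the series" means these few. Any claim that something is new, unique, unknown or untested is made for them only; others in the source may bear on it.

Values in a functional assay on SK-OV-3 cells (Homo sapiens) for antiproliferative activity, read by MTT assay, with a stated time of 72 h; a lower number here means a stronger inhibitor, a higher number a weaker inhibitor:
- compound 1 `O=C(Nc1cccc(F)c1)c1cc(=O)[nH]c2cc(-c3ccc(F)cc3)ccc12`: 16600 nM
- compound 2 `O=C(Nc1cccc(F)c1)c1cc(=O)[nH]c2cc(-c3ccsc3)ccc12`: 6700 nM

Among the measured compounds shown here, compound 2 holds the lower of the two numbers, and compound 1 is its only neighbour. Compound 3 `O=C(Nc1cccc(F)c1)c1cc(=O)[nH]c2cc(C3=CCOCC3)ccc12` differs from compound 2 in one group: a group of 6 heavy atoms (5 carbon, 1 oxygen; one six-membered non-aromatic ring with 1 hetero atom) in place of a group of 5 heavy atoms (4 carbon, 1 sulfur; one five-membered aromatic ring with 1 hetero atom), on an aromatic carbon. For the measured compounds named here, the one measured step that bears on this is a 2.5-fold lower number from compound 1 to compound 2 (0.39 log units; beyond the scatter), a modest change that also replaced one group on an aromatic carbon. That step exchanged one aromatic ring for another. Going by the values given here, no measured compound carries a non-aromatic ring in this place, so the direction is uncertain. A modest rise in this assay is expected from compound 2 at 6700 nM, no larger than the measured step. The expected change is a 1.5-fold higher number from compound 2 to compound 3 (0.17 log units; within the scatter). Compound 3 is estimated at 10000 nM, with an expected range of 4000 nM to 25000 nM.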

Compound 3, half-maximal inhibitory concentration: 13300 nM
Beside the measured number, compound 3's estimate is 1.3-fold (0.12 log units) below it, within the range that was stated.
By their numbers in this assay, from the lowest: compounds 2, 3 and 1 (each within the scatter of the next, the first and the last beyond it).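

In this assay, among the compounds shown here, compound 3 is the first with a non-aromatic ring at this position, and the change from an aromatic ring is not resolved from either neighbour: a 2.0-fold higher number from compound 2 to compound 3 (0.30 log units; within the scatter), and a 1.2-fold lower number from compound 1 to compound 3 (0.10 log units; within the scatter). An aromatic ring at this position is therefore not required for a number in the range of compound 1 and compound 2, and the step from thiophen-3-yl to this ring cannot be given a direction. No supporting measurement bears on this result.

The compounds shown leave open how an amine, such as morpholine, or a carboxylic acid would read at this position. They also leave open whether the fully saturated ring, without the double bond, would stay within the scatter of compound 3.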